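A few compounds are considered here, and "the series" means these few. Any claim that something is new, unique, unknown or untested is made for them only; others in the source may bear on it.

Of the compounds shown here, three have been measured in an ADME assay on L02 cells (Homo sapiens) for cytotoxicity, read by MTT assay, with a stated time of 24 h (a higher number here means a weaker inhibitor, a lower number a stronger inhibitor), and a fourth is still to be tested. Compound 1 has the structure `O=C1/C(=C/c2cccc(F)c2)CN(S(=O)(=O)c2ccc(Cl)cc2)C/C1=C\c1cccc(F)c1` and gives 15700 nM. Compound 2, with the structure `O=C1/C(=C/c2cccc(F)c2)CN(S(=O)(=O)c2ccc(Br)cc2)C/C1=C\c1cccc(F)c1`, gives 15800 nM. Compound 3 has the structure `O=C1/C(=C/c2ccc(F)cc2)CN(S(=O)(=O)c2ccc(Cl)cc2)C/C1=C\c1ccc(F)cc1` and gives 15500 nM. Compound 4, with the structure `O=C1/C(=C/c2ccc(F)cc2)CN(S(=O)(=O)c2ccc(Br)cc2)C/C1=C\c1ccc(F)cc1`, has no value yet.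

Compound 1 and compound 2 differ in a single place: bromo in place of chloro on an aromatic carbon The step of a 1.0-fold higher number from compound 1 to compound 2 (0.00 log units; within the scatter) shows that this exchange left the number where it was. Compound 3 is built from the same atoms as compound 1, joined differently; the difference between the two cores is not broken down here. The values of compound 1 and compound 3 sit within the scatter of each other, so the two cores cannot be told apart by this measurement.

Compound 4 stands to compound 3 exactly as compound 2 stands to compound 1: bromo in place of chloro on an aromatic carbon The place of the change reads the same, word for word, on both cores, so this is the same change made a second time. For the measured compounds named here, the pair from compound 1 to compound 2 is the only guide, and it lay within the scatter, as a 1.0-fold higher number from compound 1 to compound 2 (0.00 log units; within the scatter) shows. On that basis the expected step is a 1.0-fold higher number from compound 3 to compound 4 (0.00 log units; within the scatter). With one measured pair behind it, this expectation is modest. For compound 4 the estimated value is 15600 nM, with a likely range from 9500 nM to 25000 nM.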

Compound 4, half-maximal inhibitory concentration: 16400 nM
Estimate against measurement, compound 4: 1.1-fold (0.02 log units) below, and the stated range covers the measured number.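

In this assay, putting bromo in place of chloro on the core of compound 3 gives a 1.1-fold higher number from compound 3 to compound 4 (0.02 log units; within the scatter), so this measurement cannot tell the two compounds apart. Set beside the earlier pair, the same exchange reads alike on both cores: the same change on two cores in this assay, a 1.0-fold higher number (0.00 log units; within the scatter) from compound 1 to compound 2 and a 1.1-fold higher number (0.02 log units; within the scatter) from compound 3 to compound 4, 1.1-fold (0.02 log units) apart, within the scatter of two such steps. This shows that, in these two pairs, the exchange stayed too small to read on either core, but it does not show that a measurable effect would carry from one core to the other, as there is no measurable effect here to follow, and two cores that differ only in how their fluorines are placed are a narrow test.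

The compounds shown leave open whether a group of a different kind in the place of the chloro or bromo, such as an amine, a carboxylic acid or a longer chain, would move the number beyond the scatter in this cell assay. They also leave open whether the exchange of chloro for bromo would stay as small on a core carrying something other than fluorine on its outer rings, such as a methoxy group or a nitrile.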